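The compounds below may be only part of what the source reports. "The series", "measured", "known", "first", "only" and "open" are said of these compounds alone.

Working notes on the series, core shared by all entries.

Three compounds carry numbers in a functional assay on HeLa cells (Homo sapiens) for antiproliferative activity, with a stated time of 24 h (on this read-out higher numbers stand for weaker inhibition and lower numbers for stronger inhibition), so far. Compound 1, `NC(=O)c1c(NC(=O)c2ccc(C(F)(F)F)cc2)sc2c1CCN(Cc1ccccc1F)C2`, reaches only the limit of the assay and gives no number: compound 1 reports > 50000 nM. Compound 2, `NC(=O)c1c(NC(=O)c2cccc([N+](=O)[O-])c2)sc2c1CCN(Cc1c(Cl)cccc1Cl)C2`, gives 46100 nM. Compound 3, `NC(=O)c1c(NC(=O)c2ccccc2C(F)(F)F)sc2c1CCN(C(=S)Nc1ccccc1Cl)C2`, gives 46900 nM in this assay, the higher of the two numbers obtained, though its gap to compound 2 lies within the scatter of the method, so no order between the two can be claimed. The third entry is bounded by the limit of > 50000 nM in this assay, at which 1 of the 3 values shown sits, rather than by a number. For the measured compounds named here, no pair among the measured compounds differs in a single place, so no measured step is available to lean on.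

Compound 4, `NC(=O)c1c(NC(=O)c2ccncn2)sc2c1CCN(C(=S)Nc1ccccc1Cl)C2`, has not been measured. It differs from compound 3 by pyrimidin-4-yl in place of 2-(trifluoromethyl)phenyl on a carbonyl carbon; in words, pyrimidin-4-yl in place of 2-(trifluoromethyl)phenyl on a carbonyl carbon. Going by the values given here, nothing among the measured compounds speaks to this exchange, and all three measured entries sit at or near the top of the range, so no step beyond the scatter is expected in this assay: the expected change from compound 3 to compound 4 is a 1.1-fold higher number from compound 3 to compound 4 (0.03 log units; within the scatter). Compound 4 is estimated at 50000 nM, with a range from 20000 nM to 120000 nM, and a fair chance that only a limit is reported.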

Compound 4, half-maximal inhibitory concentration: > 50000 nM
Compound 4: only a limit was reported; the forecaster's own chance of this, stated with the estimate: 55%; the middle value sits exactly at the limit.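

For the compounds shown here, the exchange of 2-(trifluoromethyl)phenyl for pyrimidin-4-yl on a carbonyl carbon gives the first step at a single place, and in this assay the reading is an at least 1.0-fold higher number from compound 3 to compound 4 (0.02 log units; that floor lies within the scatter), a floor rather than a size. Compound 4 gives only a limit, > 50000 nM, and not a number. A ring with 2 hetero atoms and 2 hydrogen-bond acceptors in place of a ring of carbon only therefore brings no measurable gain in inhibition at this position, and the limit now holds more of the series: the limit of > 50000 nM in this assay, at which 2 of the 4 values shown sit.

From the compounds shown here alone, how far compound 4 lies past the limit cannot be read, so the true size of this step stays open. Also open, going by these compounds, is whether any other group on this carbonyl carbon, such as plain phenyl, a phenyl ring carrying a carboxylic acid, or a chain ending in an amine, would give a number clearly lower than that of compound 3 while the rest of the molecule stays the same.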